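The source may hold more compounds than are shown below. What is called first, only, known or untested is meant among the compounds shown, and "the series" means these compounds.

Measured so far:
compound 1 `COc1ccc(-c2n[nH]cc2N2CCNCC2)cc1` — > 10000 nM
compound 2 `Clc1ccc(-c2n[nH]cc2N2CCNCC2)cc1` — 1790 nM
compound 3 `Fc1ccc(-c2n[nH]cc2N2CCNCC2)cc1` — > 10000 nM

In an assay on isolated protein for binding affinity to 5-hydroxytryptamine receptor 3A (Homo sapiens) (on this read-out lower numbers stand for stronger inhibition and higher numbers for weaker inhibition), compound 3 reaches only a limit of the assay, > 10000 nM, not a number. Compound 1 likewise stops at a limit, > 10000 nM. Compound 2 gives a number, 1790 nM. Among the compounds with values here, two of the three values therefore sit at the same boundary, (the limit of > 10000 nM in this assay, at which 2 of the 3 values shown sit), and compound 2 is the only one with a readable value; the step that the two limits leave unreadable from compound 1 to compound 3 cannot be sized.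

The unmeasured compound 4 `Cc1ccc(-c2n[nH]cc2N2CCNCC2)cc1` differs from compound 3 by one exchange, (methyl in place of fluoro on an aromatic carbon). Within the data shown here, the steps that bear on this change are those among the substituents on the same aromatic carbon: an at least 5.5-fold lower number from compound 1 to compound 2 (0.74 log units; beyond the scatter) and an at least 5.5-fold higher number from compound 2 to compound 3 (0.74 log units; beyond the scatter), each beyond the scatter. Methyl has not been tested, so the only guidance is that one small substituent (chloro) lifts the value off the limit while two others (methoxy, fluoro) do not.

He therefore expects compound 4 to come off the limit at least partly, with an estimated at least 2.5-fold lower number from compound 3 to compound 4 (0.39 log units; beyond the scatter). The estimate for compound 4 is 4000 nM, within a range of 1200 nM to 15000 nM, with a real chance that it again reports only a limit.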

Compound 4, inhibition constant: > 10000 nM
Compound 4 ended at the assay's limit (the forecaster's own chance of this, stated with the estimate: 40%); at least 2.5-fold (0.39 log units) between middle value and limit.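

In this assay, methyl on this aromatic carbon, para to a large group, does not behave like chloro: the exchange of chloro for methyl gives an at least 5.5-fold higher number from compound 2 to compound 4 (0.74 log units; beyond the scatter). Within the data shown here, with methyl added to methoxy and fluoro, chloro in compound 2 is now the only one of the four groups at this position that gives a readable value, and the earlier compounds could not show that methyl would fail to do the same. The steps among compound 1, compound 3 and compound 4 cannot be read, and these three compounds cannot be placed in any order: the limit of > 10000 nM in this assay, at which 3 of the 4 values shown sit.

The compounds shown leave open whether bromo or trifluoromethyl on the same aromatic carbon would come off the limit as chloro does, or whether chloro stands alone in doing so. They also leave open how far compound 1, compound 3 and compound 4 differ from one another beyond the limit. Nor do they show whether chloro on another carbon of this ring would keep the value of compound 2, 1790 nM.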